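Working notes: stereochemical drawing step, compound 3 to compound 4

This account rests on a few compounds, and the source may have more. Where it says the series, first, only, none or still open, it means among the compounds named here.

Measured in an assay on mitochondria (strain Sprague-Dawley) for inhibition of Amine oxidase [flavin-containing] A (Rattus norvegicus), read by spectrophotometry; a higher number here means a weaker inhibitor, a lower number a stronger inhibitor:
compound 1 `Cc1c(C)c2ccc(SCc3ccccc3)cc2oc1=O` gives 10000 nM
compound 2 `Cc1ccc(S(=O)(=O)N(C)c2ccc3c(C)c(C)c(=O)oc3c2)cc1` gives 4570 nM
compound 3 `Cc1c(C)c2ccc(OC[C@@H](O)c3ccccc3)cc2oc1=O` gives 10000 nM

Compound 3 stands level with compound 1 at the digits shown; together they give the highest numbers of the three. Compound 2 gives a lower number than compound 3, a gap beyond the scatter.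

Compound 4 `Cc1c(C)c2ccc(OCC(O)c3ccccc3)cc2oc1=O` is not yet measured. Compared with compound 3: the two compounds have the same atoms and bonds; at least one stereo element is drawn with a configuration in one of them and without one in the other: 1 of 1 stereo elements differ; a stereocentre at a saturated chain carbon is drawn S in compound 3 and without a configuration in compound 4. Among the compounds with values here, no step between measured compounds is available as a guide, and the atoms and bonds are unchanged, so in this assay no step beyond the scatter is expected in either direction. Compound 4 is therefore estimated at 10000 nM, range 5000 nM to 20000 nM, an expected step of no change at the digits printed from compound 3 to compound 4 (within the scatter).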

Compound 4, half-maximal inhibitory concentration: 10000 nM
Compound 4: the middle estimate sits on the measured number at the digits printed; low and high end bracket the measured number.
By their numbers in this assay, from the lowest: compound 2; then compounds 1, 3 and 4 (each within the scatter of the next).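

The first step available in this assay reads no change at the digits printed from compound 3 to compound 4 (within the scatter). At this saturated chain carbon, a drawing with the S configuration and a drawing without a configuration therefore read alike. The reach of this comparison is set by one fact: the fact that one of compounds 3 and 4 is drawn with a defined configuration and the other without, at the place where they differ

On these data alone, the drawing of compound 4 does not tell which configuration or mixture was tested, so the effect of the configuration itself stays open. Also open, as far as these compounds go, is how this assay would respond to an amine or a carboxylic acid in place of the hydroxyl on this chain.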